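This account rests on a few compounds, and the source may have more. Where it says the series, first, only, none or still open, it means among the compounds named here.

Of the compounds shown here, three of this set have been measured in an ADME assay on HepG2 cells (Homo sapiens) for cytotoxicity, read by MTT assay, with a stated time of 72 h; a higher number here means that more compound is tolerated, a lower number that less compound is tolerated. Compound 1 `O=[N+]([O-])c1c(CS(=O)(=O)c2ccccc2)nc2c(-c3ccccc3)cc(Cl)cn12` gives only a limit of the assay, > 15600 nM. Compound 2 `N#Cc1ccc(-c2cc(Cl)cn3c([N+](=O)[O-])c(CS(=O)(=O)c4ccccc4)nc23)cc1` likewise gives only a limit, > 3900 nM. Compound 3 `O=[N+]([O-])c1c(CS(=O)(=O)c2ccccc2)nc2c(-c3cccc(CO)c3)cc(Cl)cn12` also gives only a limit, > 25000 nM. Compound 2 therefore stands among three values that are all limits, none of them a number, and the steps between them are a step that the two limits leave unreadable from compound 1 to compound 2, a step that the two limits leave unreadable from compound 1 to compound 3 and a step that the two limits leave unreadable from compound 2 to compound 3, none with a readable size.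

Compound 4 `O=[N+]([O-])c1c(CS(=O)(=O)c2ccccc2)nc2c(-c3cccc(C(F)(F)F)c3)cc(Cl)cn12` differs from compound 2 in one place: 3-(trifluoromethyl)phenyl in place of 4-cyanophenyl on an aromatic carbon. Of the measured steps, a step that the two limits leave unreadable from compound 2 to compound 3 bears most directly, as it too removes 4-cyanophenyl from an aromatic carbon. The step that the two limits leave unreadable from compound 1 to compound 2 touches the same group. Both sizes stay hidden behind limits. No readable step points in either direction, so no movement beyond the scatter is expected in this assay. Compound 4 is therefore estimated at 20000 nM, with a range from 5000 nM to 60000 nM, and most probably again reported only as a limit. The expected step is a step that the limit leaves unreadable from compound 2 to compound 4.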

Compound 4, half-maximal cytotoxic concentration: > 12500 nM
Compound 4: only a limit was reported; the forecaster's own chance of this, stated with the estimate: 85%; the middle value does not contradict the limit.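

Compound 4 gives only a limit, > 12500 nM. Its steps to compound 1, compound 2 and compound 3 cannot be read: all four values are limits. The compounds shown leave open at what concentration any of the four becomes cytotoxic, and whether changing this aromatic substituent shifts that concentration at all.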